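Benzyl ether replacing the aryl ester at the ring oxygen

The source may hold more compounds than are shown below. What is called first, only, known or untested is meant among the compounds shown, and "the series" means these compounds.

In a functional assay on A-375 cells (Homo sapiens) for antiproliferative activity, read by MTT assay, with a stated time of 24 h (on this read-out lower numbers stand for stronger inhibition and higher numbers for weaker inhibition), compound 1 `COc1cccc(C(=O)Oc2ccc3c(=O)c(-c4cc(OC)c(OC)cc4OC)coc3c2)c1` gives only a limit, > 10000 nM, so its position on the scale is known from one side alone (the limit of > 10000 nM in this assay, at which 1 of the 3 values shown sits). The two benzyl ethers are measured as numbers: in this assay compound 2 `COc1cc(OC)c(-c2coc3cc(OCc4ccc(Br)cc4)ccc3c2=O)cc1OC` gives 1000 nM, and compound 3 `COc1cc(OC)c(-c2coc3cc(OCc4cccc(F)c4)ccc3c2=O)cc1OC` gives 1300 nM. Both steps away from the ester run the same way: an at least 10-fold lower number from compound 1 to compound 2 (1.00 log units; beyond the scatter) and an at least 7.6-fold lower number from compound 1 to compound 3 (0.88 log units; beyond the scatter). Between the two ethers the halogen on the benzyl ring matters little, a 1.3-fold higher number from compound 2 to compound 3 (0.11 log units; within the scatter).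

Compound 4 `COc1cc(OC)c(-c2coc3cc(OCc4ccccc4Cl)ccc3c2=O)cc1OC` is not yet measured. Relative to compound 1 the change is 2-chlorobenzyl in place of (3-methoxyphenyl)carbonyl on an oxygen on an aromatic ring. It is the same kind of exchange as in the two measured steps from compound 1, the ester leaving and a halogenated benzyl entering at the same oxygen, so those two steps and the small gap between compound 2 and compound 3 bear on it directly. A drop beyond the scatter is therefore expected, and the expected size of the step is an at least 8.3-fold lower number from compound 1 to compound 4 (0.92 log units; beyond the scatter). For compound 4 the estimate in this assay is 1200 nM, with a range from 500 nM to 3000 nM, expected to land near the two measured ethers rather than at the limit.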

Compound 4, half-maximal inhibitory concentration: 2020 nM
Compound 4: the middle estimate sits 1.7-fold (0.23 log units) below what was measured; the range from low to high includes it.
By their numbers in this assay, from the lowest: compounds 2, 3 and 4 (each within the scatter of the next, the first and the last beyond it). At a limit, above all of these: compound 1.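

A third halogenated benzyl ether, 2-chlorobenzyl, keeps the gain over the ester at this oxygen, with an at least 4.9-fold lower number from compound 1 to compound 4 (0.69 log units; beyond the scatter), so in this assay the exchange now holds for all three ethers shown. For compound 1 the figure is a limit, so each step from it gives a bound and not a size: the limit of > 10000 nM in this assay, at which 1 of the 4 values shown sits. Among the ethers the first spread beyond the scatter appears, though it is small: the step to 2-chlorobenzyl reads a 1.6-fold higher number from compound 3 to compound 4 (0.19 log units; within the scatter), which stays within the scatter, and a 2.0-fold higher number from compound 2 to compound 4 (0.31 log units; beyond the scatter), which only just passes it, so the substituted benzyl ring is not entirely silent in this series.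

Halogen and ring location change together across compounds 2, 3 and 4, so the compounds shown cannot separate the two. Going by these compounds, it stays open whether this level of activity would hold with an amine or a carboxylic acid on the benzyl ring, or with a longer chain in place of the benzyl group on this oxygen.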